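Phenyl for benzyl on the ring amide nitrogen

The source may report more compounds than this note shows. Statements on the series, on what has been measured and on what is new or still open speak of the compounds shown alone.

Compound 2 `COc1ccc(N(C(=O)CN2C=CN(Cc3ccccc3)C(=O)C(Cc3n[nH]c4ccccc34)C2=O)C(C)C)cc1` stands at the high end of the two numbers measured: in a functional assay on CHO cells for agonist activity at Melanocyte-stimulating hormone receptor (Homo sapiens), read by a luciferase reporter, with a stated time of 4 h (a lower number here means that less compound is needed, a higher number that more compound is needed for the effect), compound 2 gives 794 nM, whereas compound 1 `COc1ccc(N(C(=O)CN2C=CN(c3ccccc3)C(=O)[C@H](Cc3n[nH]c4ccccc34)C2=O)C(C)C)cc1` gives 15.9 nM, a gap beyond the scatter. Compound 3 `COc1ccc(N(C(=O)CN2C=CN(c3ccccc3)C(=O)C(Cc3n[nH]c4ccccc34)C2=O)C(C)C)cc1` is not yet measured. Its change from compound 2 is phenyl in place of benzyl on an amide-type nitrogen in a ring, and compound 3 thereby carries the same phenyl on the ring nitrogen as compound 1. A large step downward is expected, a 26-fold lower number from compound 2 to compound 3 (1.42 log units; beyond the scatter), since compound 1 with that phenyl gives 15.9 nM. Compound 3 is estimated at 30 nM, within 10 nM to 100 nM.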

Compound 3, half-maximal effective concentration: 29.5 nM
For compound 3 the middle estimate is 1.0-fold (0.01 log units) above the measured one; measured number inside the range.
By their numbers in this assay, from the lowest: compounds 1 and 3 (each within the scatter of the next); then compound 2.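

On the ring amide nitrogen, the change from benzyl to phenyl in this assay gives a 27-fold lower number from compound 2 to compound 3 (1.43 log units; beyond the scatter), so this position responds strongly to that change when nothing else in the structure differs. Compound 1 and compound 2 could not show this alone, since they also differ in how the saturated ring carbon is drawn. The stereo contrast itself gives only a 1.9-fold higher number from compound 1 to compound 3 (0.27 log units; within the scatter), and it rests on this: the fact that one of compounds 1 and 3 is drawn with a defined configuration and the other without, at the place where they differ

As far as these compounds go, how the separate configurations at that carbon compare remains open. Also open, from the compounds shown here alone, is how a longer chain ending in an amine, or a carboxylic acid, would fare on the ring nitrogen.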